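The source may hold more compounds than are shown below. What is called first, only, known or untested is meant among the compounds shown, and "the series" means these compounds.

Two compounds of the series carry numbers in an ADME assay on microsomes from liver (Mus musculus, strain CD1) for metabolic stability, read by HPLC, using NADPH, with a stated time of 30 min; a higher number here means faster removal of the compound, a lower number slower removal. Compound 1 `COc1cccc(NC(=O)c2nnn(Cc3ccc(SC)cc3)c2N)c1` gives 6.4 mL.min-1.g-1 in this assay. Compound 2 `COc1cccc(NC(=O)c2nnn(CC3CCN(C(=O)OC(C)(C)C)CC3)c2N)c1` gives 10 mL.min-1.g-1 in this assay. Within the data shown here, compound 1 sits at one end of these two numbers, and compound 2, the only neighbour, stands within the scatter of it, so the two values do not separate. Among the measured compounds shown here, no step between measured compounds is available that shows how a change at the benzylic ring alters clearance. Compound 3 `COc1cccc(NC(=O)c2nnn(Cc3ccc(C(C)C)cc3)c2N)c1` differs from compound 1 by isopropyl in place of methylsulfanyl on an aromatic carbon; the rest of the molecule stays as it is. With nothing in the measured pair to read across from, the step expected from compound 1 to compound 3 is a 1.3-fold higher number from compound 1 to compound 3 (0.10 log units; within the scatter), which is not expected to reach beyond the scatter. Compound 3 is estimated to give 8 mL.min-1.g-1 in this assay, with a range from 4 mL.min-1.g-1 to 16 mL.min-1.g-1.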

Compound 3, intrinsic clearance in microsomes: 3.2 mL.min-1.g-1
Compound 3: the middle estimate sits 2.5-fold (0.40 log units) above what was measured; the whole stated range lies above it.
By their numbers in this assay, from the lowest: compounds 3, 1 and 2 (each within the scatter of the next, the first and the last beyond it).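

Among these compounds, on an aromatic carbon para to a large group, isopropyl in place of methylsulfanyl gives the only step read at this position in this assay: a 2.0-fold lower number from compound 1 to compound 3 (0.30 log units; within the scatter). This pair therefore does not separate, and a group of carbon only at this place cannot be told apart from the sulfur-bearing methylsulfanyl. No measurement bears on what lies behind this result.

The compounds shown leave open whether a carboxylic acid, an amine or a longer alkyl chain on the same carbon would move the number in this assay beyond the scatter. They also leave open whether isopropyl and methylsulfanyl would stay this close on a core carrying a different group in place of the 3-methoxyphenyl amide.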